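A few compounds are considered here, and "the series" means these few. Any claim that something is new, unique, unknown or untested is made for them only; others in the source may bear on it.

Measured so far in a functional assay on the whole organism (strain Wister albino) for inhibition, with Rattus norvegicus as the target, read by paw edema, with a stated time of 1 h, at a dose of 50 mg/kg by the intraperitoneal route; on this read-out lower numbers stand for less inhibition and higher numbers for more inhibition at the one dose given (going by the name of the read-out):
compound 1, `CCOC(=O)c1c(-c2ccc(Cl)cc2)cc(-c2ccccc2)nc1N1CCCCC1`: 59.3%
compound 2, `CCOC(=O)c1c(-c2ccc(Cl)c(Cl)c2)cc(-c2ccccc2)nc1N1CCCCC1`: 53.5%

For the measured compounds named here, compound 1 gives the higher of the two numbers, but its only neighbour, compound 2, is separated from it by a number 5.8 percentage points lower from compound 1 to compound 2 (within the scatter), so the two compounds are not told apart and neither can be said to give the higher inhibition in this assay.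

Compound 3, `CCOC(=O)c1c(-c2ccc(Cl)cc2)cc(-c2ccccc2)nc1N1CCN(C)CC1`, has not been measured. It differs from compound 1 by 4-methylpiperazin-1-yl in place of piperidin-1-yl on an aromatic carbon. Going by the values given here, the one step measured so far concerns a chloro in place of hydrogen on an aromatic carbon and came out as a number 5.8 percentage points lower from compound 1 to compound 2 (within the scatter); it says nothing about an exchange of the ring attached to the core. Among the compounds with values here, no measured step therefore bears on the change from compound 1 to compound 3, and no step beyond the scatter is expected in either direction.

Compound 3 is estimated at 55%, with a range of 40% to 70%. This estimate means a step of a number 4.3 percentage points lower from compound 1 to compound 3 (within the scatter), expected to lie within the scatter; the range is kept wide because nothing measured in this assay speaks to the new ring.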

Compound 3, a percentage reported as inhibition, in the whole organism at one dose (the size of the read-out at that dose, not a potency): 65.8%
Compound 3: the middle estimate sits 10.8 percentage points below what was measured, within the range that was stated.
By their numbers in this assay, from the lowest: compounds 2, 1 and 3 (each within the scatter of the next, the first and the last beyond it).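

In this assay, the exchange of piperidin-1-yl for 4-methylpiperazin-1-yl on the aromatic carbon next to the ring nitrogen, ortho to the ethoxycarbonyl group, comes out as a number 6.5 percentage points higher from compound 1 to compound 3 (within the scatter) and does not tell the two rings apart. For the compounds shown here, this is the first reading at this position, where the earlier compounds differed only on the aryl group: a second ring nitrogen carrying a methyl can stand here, in this one pair, with no step beyond the scatter. Nothing measured on the compounds themselves bears on what lies behind this reading, and so the result stays a bare observation on one pair.

Going by these compounds, open at this same carbon is whether a piperazin-1-yl ring with a free amine, a morpholin-4-yl ring or an open-chain dimethylamino group would give a step beyond the scatter, so the width of what this position accepts is still unknown. Also open, on these data alone, is whether the same ring exchange reads alike on the core of compound 2, and whether a carboxylic acid in place of the ethoxycarbonyl group changes the picture at the neighbouring position.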